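Replacing dimethylamino with fluoro in compound 1

The source may hold more compounds than are shown below. What is called first, only, known or untested is meant among the compounds shown, and "the series" means these compounds.

Measured in a functional assay on HeLa cells (Homo sapiens) for antiproliferative activity, read by MTT assay, with a stated time of 48 h; on this read-out lower numbers stand for stronger inhibition of growth and higher numbers for weaker inhibition of growth
compound 1 `Cc1cc2c(c(=O)n1C)C(c1ccc(N(C)C)c(Br)c1)C(C#N)=C(N)O2` gives 330 nM
compound 2 `COc1cc(C2C(C#N)=C(N)Oc3cc(N(C)C)ccc32)cc(OC)c1OC` gives 17 nM

Compound 1 at 330 nM has the higher number of the two, and compound 2 at 17 nM the lower, a gap beyond the usual scatter. These two compounds differ in more than one place, so the gap does not isolate any single change.

Compound 3 `Cc1cc2c(c(=O)n1C)C(c1ccc(F)c(Br)c1)C(C#N)=C(N)O2` keeps the core of compound 1 but has fluoro in place of dimethylamino on an aromatic carbon and this carbon is ortho to a bromo group.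

For the measured compounds named here, no measured pair shows this change. Going by the values given here, compound 2 at 17 nM also carries dimethylamino, and no measured compound carries fluoro, so the expectation is loose. In this assay a moderate move towards weaker inhibition of growth is expected, with the estimated step of a 3.0-fold higher number from compound 1 to compound 3 (0.48 log units; beyond the scatter) as the size of that move. For compound 3 the estimate is 1000 nM within an expected range of 250 nM to 5000 nM for the measurement.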

Compound 3, concentration for 50% growth inhibition: 6400 nM
Compound 3: middle estimate off by 6.4-fold (0.81 log units), on the low side; measured number above the stated range.
By their numbers in this assay, from the lowest: compound 2; then compound 1; then compound 3.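

In this assay, for the compounds shown here, putting fluoro in place of dimethylamino on this aromatic carbon, ortho to a bromo group and para to a large group, gives a 19-fold higher number from compound 1 to compound 3 (1.29 log units; beyond the scatter) and is the first change here that can be read in isolation. With the rest of the molecule held fixed, it shows that the group at this position matters on its own, and that of these two groups, dimethylamino goes with the stronger inhibition of growth. There is no evidence here on why the change has this effect.

On these data alone, it remains open how an unsubstituted amino group, a methoxy group or diethylamino would behave at this position, and so whether dimethylamino is unusually favourable or fluoro unusually poor. As far as these compounds go, it is also open whether the same swap would produce a step of similar size on a different core.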